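The source may hold more compounds than are shown below. What is called first, only, known or untested is meant among the compounds shown, and "the series" means these compounds.

Compound 1 `Cc1cc(C)c(S(=O)(=O)c2cc(C)c(C)cc2C)c(C)c1` gives 700 nM in an assay on isolated protein for antagonist activity at Rap guanine nucleotide exchange factor 4 (Homo sapiens), read by fluorescence and cAMP accumulation; a lower number here means a stronger inhibitor, a higher number a weaker inhibitor. Compound 2 `Cc1cc(C)c(S(=O)(=O)c2ccc(C3CCCCC3)cc2)c(C)c1` reaches only a limit of this assay, > 300000 nM. Compound 3 `Cc1cc(C)c(S(=O)(=O)c2ccc(-c3ccc(F)nc3)cc2)c(C)c1` likewise reaches only a limit, > 300000 nM, and so it stands at the limit of > 300000 nM in this assay, at which 2 of the 3 values shown sit. The step that the two limits leave unreadable from compound 2 to compound 3 therefore cannot be read. Compound 4 `Cc1cc(C)c(S(=O)(=O)c2ccc(OCCN)cc2)c(C)c1` differs from compound 3 by 2-aminoethoxy in place of 6-fluoropyridin-3-yl on an aromatic carbon. For the measured compounds named here, no measured step bears on this change: the one step available is unreadable, and compound 1 supplies the only number in this assay. Compound 4 is expected to stay weak, with an estimated step of an at least 2.0-fold lower number from compound 3 to compound 4 (0.30 log units; that floor lies within the scatter) that may again end at a limit. Compound 4 is estimated at 150000 nM, expected to lie between 20000 nM and 300000 nM.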

Compound 4, half-maximal inhibitory concentration: > 300000 nM
Compound 4: only a limit was reported (the forecaster's own chance of this, stated with the estimate: 60%); middle value at least 2.0-fold (0.30 log units) away from the limit.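

Compound 2, compound 3 and compound 4 all sit at a limit of this assay, so no step among these three compounds can be read. The compounds shown leave open how far compound 2, compound 3 and compound 4 differ from one another.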